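Switching the aryl ether arm of compound 2 to a thiazole

The source may hold more compounds than are shown below. What is called first, only, known or untested is meant among the compounds shown, and "the series" means these compounds.

Compound 1 `CC(C)(C)Sc1c(CC(C)(C)C(=O)O)n(Cc2ccc(Cl)cc2)c2ccc(CCc3ccc4ccccc4n3)cc12` shows no measurable effect in a functional assay (blood) for inhibition, with Homo sapiens as the target; on this read-out lower numbers stand for stronger inhibition and higher numbers for weaker inhibition: the value for compound 1 is reported only as the limit > 3000 nM. Compound 2 `CC(C)(C)Sc1c(CC(C)(C)C(=O)O)n(Cc2ccc(Cl)cc2)c2ccc(OCc3ccc4cc(F)c(F)cc4n3)cc12` stands in the same place, as its result in this assay is likewise the limit > 3000 nM. Both results therefore sit at the same point, as the limit of > 3000 nM in this assay, at which 2 of the 2 values shown sit, notes. Compound 3 `CC(C)c1csc(COc2ccc3c(c2)c(SC(C)(C)C)c(CC(C)(C)C(=O)O)n3Cc2ccc(Cl)cc2)n1` differs from compound 2 by a group of 8 heavy atoms (6 carbon, 1 nitrogen, 1 sulfur; one five-membered aromatic ring with 2 hetero atoms) in place of a group of 12 heavy atoms (9 carbon, 1 nitrogen, 2 fluorine; one six-membered aromatic ring of carbon only, one six-membered aromatic ring with 1 hetero atom), on a saturated chain carbon bound to an oxygen on an aromatic ring. Going by the values given here, with no measured step between any two compounds, no shift beyond the scatter is expected, and the step from compound 2 to compound 3 is estimated at a number no higher from compound 2 to compound 3 (the limit leaves the size open). In this assay compound 3 is expected to give about 3000 nM, between 1200 nM and 8000 nM.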

Compound 3, half-maximal inhibitory concentration: > 3000 nM
Compound 3: only a limit was reported (the forecaster's own chance of this, stated with the estimate: 65%); the middle value sits exactly at the limit.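

Compound 3, like compound 1 and compound 2, gives only a limit in this assay, so no step between these compounds can be read: the limit of > 3000 nM in this assay, at which 3 of the 3 values shown sit.

The compounds shown leave open how strongly each inhibits, and whether the 4-isopropyl-1,3-thiazol-2-yl group makes any difference.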